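Swapping Dichlorophenyl for Dimethoxyphenyl on the Saturated Ring Carbon

The source may report more compounds than this note shows. Statements on the series, on what has been measured and on what is new or still open speak of the compounds shown alone.

Going by the values given here, compound 2 `COc1cc(C2=NN(C(C)=O)C(c3cc(Cl)cc(Cl)c3)O2)cc(OC)c1OC` gives the higher of the two numbers known so far: in a functional assay on PC-3 cells (Homo sapiens) for antiproliferative activity, read by MTT assay, tested at 1 uM (on this read-out higher numbers stand for a stronger effect at the one concentration tested and lower numbers for a weaker effect), compound 2 reaches 52.7%, while compound 1 `COc1cc(C(=O)N/N=C/c2ccc(F)c(F)c2)cc(OC)c1OC` in this assay gives 35.1%, a gap beyond the usual scatter. Compound 3 `COc1ccc(C2OC(c3cc(OC)c(OC)c(OC)c3)=NN2C(C)=O)c(OC)c1` is not yet measured and differs from compound 2 in one place: 2,4-dimethoxyphenyl in place of 3,5-dichlorophenyl on a saturated ring carbon. Among the compounds with values here, no measured pair shows how this exchange acts, so the step is expected to be small, a number 7.7 percentage points lower from compound 2 to compound 3 (within the scatter), probably within the scatter in either direction. Compound 3 is thus expected to give about 45%, within a range from 25% to 65%.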

Compound 3, a percentage reported as inhibition, at one concentration (the size of the read-out at that concentration, not a potency): 69.5%
Beside the measured number, compound 3's estimate is 24.5 percentage points below it; measured number above the stated range.
By their numbers in this assay, from the lowest: compound 1; then compound 2; then compound 3.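

This saturated ring carbon is sensitive to the choice of aromatic group: in this assay, 2,4-dimethoxyphenyl in place of 3,5-dichlorophenyl gives a number 16.8 percentage points higher from compound 2 to compound 3 (beyond the scatter). The exchange adds oxygen-bearing methoxy groups and removes both chlorines, and the effect at the one concentration tested still rises, although this is a single pair. Nothing available explains this step.

Going by these compounds, it remains open whether both methoxy groups are needed, or whether one alone would do as well. A phenyl ring carrying an amine, such as dimethylamino, also remains untested in the compounds shown here.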